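A few compounds are considered here, and "the series" means these few. Any claim that something is new, unique, unknown or untested is made for them only; others in the source may bear on it.

The series rests on a shared core, `C=CCCCCCS(=O)(=O)/C=C/c1ccc(O)c(O)c1` for compound 1, `CCCCCCS(=O)(=O)/C=C/c1ccc(O)c(O)c1` for compound 2 and `O=S(=O)(/C=C/c1ccc(O)c(O)c1)CCCCCCCCCCCO` for compound 3. In a functional assay, read by fluorescence and spectrophotometry, with a stated time of 1 h (on this read-out higher numbers stand for an effect only at larger amounts of compound and lower numbers for an effect already at smaller amounts), compound 1 gives 7100 nM, compound 2 gives 7300 nM and compound 3 gives 22600 nM, the highest of the three numbers: a 3.1-fold higher number from compound 2 to compound 3 (0.49 log units; beyond the scatter) and a 3.2-fold higher number from compound 1 to compound 3 (0.50 log units; beyond the scatter). Compound 4, `O=S(=O)(/C=C/c1ccc(O)c(O)c1)CCCCCCCCCO`, differs from compound 3 by hydroxy in place of 2-hydroxyethyl on a saturated chain carbon, nine bonds along the chain from a sulfonyl sulfur. The step that bears most on this change is a 3.1-fold higher number from compound 2 to compound 3 (0.49 log units; beyond the scatter), where 5-hydroxypentyl takes the place of hydrogen; compound 4 keeps the hydroxy on a shorter chain, so a partial return toward compound 2 is possible but should not exceed that step. Compound 4 is therefore expected to give about 16000 nM, between 6000 nM and 40000 nM, a change of a 1.4-fold lower number from compound 3 to compound 4 (0.15 log units; within the scatter) that is estimated to stay close to the scatter.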

Compound 4, half-maximal effective concentration: 7500 nM
Compound 4: middle estimate off by 2.1-fold (0.33 log units), on the high side; measured number inside the range.
By their numbers in this assay, from the lowest: compounds 1, 2 and 4 (each within the scatter of the next); then compound 3.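

The step of a 3.0-fold lower number from compound 3 to compound 4 (0.48 log units; beyond the scatter) shows that, with hydroxy in place of 2-hydroxyethyl, the length of the chain carrying the hydroxy matters at this position. Alongside a 1.0-fold higher number from compound 2 to compound 4 (0.01 log units; within the scatter) and a 1.1-fold higher number from compound 1 to compound 4 (0.02 log units; within the scatter) it also shows that a hydroxy on the chain does not by itself go with a higher number, since only the longer chain of compound 3 stands apart. Nothing available explains this result. As far as these compounds go, whether an amine or a carboxylic acid in place of the hydroxy would behave alike remains open, as does the effect of a still longer chain.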